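Compound 1 to compound 4: exchange on the sulfur

The source may hold more compounds than are shown below. What is called first, only, known or untested is meant among the compounds shown, and "the series" means these compounds.

Measured so far:
- compound 1 `CC1=NN(C(=O)CSc2ccccn2)[C@@H](c2cc(Br)cc(Br)c2O)C1`: 12300 nM
- compound 2 `O=C(CSCc1ccco1)N1N=C(c2cc3ccccc3oc2=O)C[C@@H]1c1ccccc1C(F)(F)F`: 15700 nM
- compound 3 `CCCCSCC(=O)N1N=C(c2cc3ccccc3oc2=O)C[C@@H]1c1ccccc1`: 12900 nM

All three values come from a functional assay on MGC-803 cells (Homo sapiens) for cytotoxicity, read by MTT assay, with a stated time of 48 h; on this read-out higher numbers stand for weaker inhibition and lower numbers for stronger inhibition. Compound 1, at 12300 nM, stands within the scatter of both compound 2 and compound 3, so these data give it no rank of its own. Compound 4 `CC1=NN(C(=O)CSc2nc3ccccc3s2)[C@@H](c2cc(Br)cc(Br)c2O)C1` keeps the core of compound 1 and changes one group: 1,3-benzothiazol-2-yl in place of pyridin-2-yl on a sulfur. Going by the values given here, no measured pair isolates this exchange, so its effect is unknown. Among the compounds with values here, the only guide is that compound 2 at 15700 nM and compound 3 at 12900 nM stay close to compound 1 despite their different structures. The expected step is a 1.2-fold lower number from compound 1 to compound 4 (0.09 log units; within the scatter), with no change beyond the scatter anticipated. For compound 4 the estimated value is 10000 nM, with an expected range from 3500 nM to 25000 nM.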

Compound 4, half-maximal inhibitory concentration: 7800 nM
Compound 4: middle estimate off by 1.3-fold (0.11 log units), on the high side; measured number inside the range.
By their numbers in this assay, from the lowest: compounds 4, 1, 3 and 2 (each within the scatter of the next).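

In this assay, going by these compounds alone, this is the first pair that differs in one place, and the exchange on the sulfur gives a 1.6-fold lower number from compound 1 to compound 4 (0.20 log units; within the scatter). The sulfur, whose other neighbour is a saturated chain carbon, therefore carries either the single six-membered aromatic ring of pyridin-2-yl or the larger 1,3-benzothiazol-2-yl, with its five-membered and six-membered aromatic rings, with no change beyond the scatter on the core of compound 1. No measurement of any property of the two groups is available to bear on this result.

On these data alone, whether an amine, a carboxylic acid or a longer chain on this sulfur would move the number beyond the scatter remains open. Also open, as far as these compounds go, is whether the same exchange would give a similar step on the core of compound 3.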